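A few compounds are considered here, and "the series" means these few. Any claim that something is new, unique, unknown or untested is made for them only; others in the source may bear on it.

Among the three compounds measured, compound 3 `COc1ccccc1N1CCN(CCCN2C(=O)CC(=C(c3ccccc3)c3ccccc3)C2=O)CC1` gives the lowest number in an assay on membranes from Cerebral cortex for binding affinity to Adrenergic receptor alpha-1 (Rattus norvegicus), read by radioligand binding (on this read-out lower numbers stand for stronger inhibition and higher numbers for weaker inhibition), at 8.1 nM, while compound 1 `COc1ccccc1N1CCN(CCN2C(=O)CC(=C(c3ccccc3)c3ccccc3)C2=O)CC1` gives 71.5 nM and compound 2 `O=C1CC(=C(c2ccccc2)c2ccccc2)C(=O)N1CCN1CCN(c2ccc(F)cc2)CC1` gives 529 nM. Compound 4 `O=C1CC(=C(c2ccccc2)c2ccccc2)C(=O)N1CCCN1CCN(c2ccc(F)cc2)CC1` has not yet been measured; it differs from compound 3 by 4-fluorophenyl in place of 2-methoxyphenyl on an amine nitrogen in a ring. The same exchange has already been made once within this set, where a 7.4-fold higher number from compound 1 to compound 2 (0.87 log units; beyond the scatter). For the measured compounds named here, that single step is the only direct guide, and the expectation is that compound 4 follows it in this assay, with a weaker result of comparable size. For compound 4 the expected step is a 7.4-fold higher number from compound 3 to compound 4 (0.87 log units; beyond the scatter). Compound 4 is therefore estimated at about 60 nM, with a range from 25 nM to 150 nM.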

Compound 4, inhibition constant: 8.3 nM
Estimate against measurement, compound 4: 7.2-fold (0.86 log units) above, and the stated range ends above it.
By their numbers in this assay, from the lowest: compounds 3 and 4 (each within the scatter of the next); then compound 1; then compound 2.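

In this assay, putting 4-fluorophenyl in place of 2-methoxyphenyl gives a 1.0-fold higher number from compound 3 to compound 4 (0.01 log units; within the scatter), so on the core of compound 3 this exchange on the ring amine nitrogen leaves the number unchanged within the scatter. The outcome of the exchange therefore depends on the core that carries it, and one step could not have shown this: the same change on two cores in this assay, a 7.4-fold higher number (0.87 log units; beyond the scatter) from compound 1 to compound 2 and a 1.0-fold higher number (0.01 log units; within the scatter) from compound 3 to compound 4, 7.2-fold (0.86 log units) apart, beyond the scatter of two such steps

The compounds shown leave open whether a longer chain would also keep these two groups level. They also leave open whether a 2-chlorophenyl or a pyridyl group at this place would behave like either of them.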